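Trimming a Side Chain on the Shared Core

A few compounds are considered here, and "the series" means these few. Any claim that something is new, unique, unknown or untested is made for them only; others in the source may bear on it.

Compound 1 `CCCCCc1cc2c(=O)n(CCCSc3nc(-c4cc(OC)c(OC)c(OC)c4)c(C#N)c(=O)[nH]3)cnc2s1` and compound 2 `CCCCCCCc1cc2c(=O)n(CCCSc3nc(-c4cc(OC)c(OC)c(OC)c4)c(C#N)c(=O)[nH]3)cnc2s1` share one core and differ only in the length of a chain. In an ADME assay on THP-1 cells (Homo sapiens) for inhibition, read by MTT assay (on this read-out higher numbers stand for weaker inhibition of growth and lower numbers for stronger inhibition of growth), compound 1 reaches only > 100 ug/mL, which is a limit of the assay and not a number. In this assay, for the measured compounds named here, compound 2 gives 68.2 ug/mL, the only number in the set, and the step of an at least 1.4-fold lower number from compound 1 to compound 2 (0.16 log units; that floor lies within the scatter) has a floor within the scatter. Compound 3 `CCCc1cc2c(=O)n(CCCSc3nc(-c4cc(OC)c(OC)c(OC)c4)c(C#N)c(=O)[nH]3)cnc2s1` carries the change (hydrogen in place of butyl on a saturated chain carbon, three bonds along the chain from an aromatic carbon), running the opposite way and further than compound 1. Since compound 1 sat at the limit of > 100 ug/mL in this assay, at which 1 of the 2 values shown sits, compound 3 is expected to show a 2.2-fold higher number from compound 2 to compound 3 (0.34 log units; beyond the scatter), toward weaker inhibition and likely another limit. The estimate for compound 3 is 150 ug/mL, ranging from 60 ug/mL to 400 ug/mL.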

Compound 3, concentration for 50% growth inhibition: > 100 ug/mL
Compound 3 ended at the assay's limit; the forecaster's own chance of this, stated with the estimate: 70%; the middle value is on the limit's open side.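

In this assay, cutting the chain from heptyl to propyl gives an at least 1.4-fold higher number from compound 2 to compound 3 (0.16 log units; that floor lies within the scatter), so this change, like the earlier one, yields only a floor and no measured size. The step between the pentyl and propyl compounds cannot be read, as both values are limits of the assay and not numbers. Of the three chains shown, only heptyl gives a number, and the two shorter chains share one limit: the limit of > 100 ug/mL in this assay, at which 2 of the 3 values shown sit.

The compounds shown leave open whether a chain longer than heptyl would lower the number beyond the scatter. They also leave open whether an amine at this position would give a number at all.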